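Shortening a chain linker on a cholesterol transporter binder

The source may report more compounds than this note shows. Statements on the series, on what has been measured and on what is new or still open speak of the compounds shown alone.

Measured so far:
Compound 1 `CC(C)(C)OC(=O)NCCCCNC(=O)CN1CN(c2ccccc2)C2(CCN(C(=O)c3ccc(C4CCCCC4)cc3)CC2)C1=O` gives 4600 nM in an assay on HEK293 cells for displacement of a labelled ligand from NPC1-like intracellular cholesterol transporter 1 (Homo sapiens); a lower number here means a stronger inhibitor, a higher number a weaker inhibitor.
Compound 2 `CC(C)(C)OC(=O)NCCCCNC(=O)CN1CN(c2ccccc2)C2(CCN(C(=O)c3ccc(C(C)(C)C)cc3)CC2)C1=O` has "not determined" (no result reported) in this assay.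
Compound 3 `CC(C)(C)c1ccc(C(=O)N2CCC3(CC2)C(=O)N(CC(=O)N2CCN(S(C)(=O)=O)CC2)CN3c2ccccc2)cc1` gives 19000 nM in this assay.

Of the two numbers, compound 1 holds the lower one; compound 3 sits higher by a gap beyond the usual scatter, so compound 1 is the stronger binder of the two. Compound 4 `CC(C)(C)OC(=O)NCCCNC(=O)CN1CN(c2ccccc2)C2(CCN(C(=O)c3ccc(C4CCCCC4)cc3)CC2)C1=O` is compound 1 with (tert-butoxycarbonyl)amino in place of ((tert-butoxycarbonyl)amino)methyl on a saturated chain carbon, three bonds along the chain from an amide-type nitrogen. Going by the values given here, no step between measured compounds is available to guide this change. A shortening of the chain by this much is expected to move the result little, in no clear direction and not beyond the scatter, and the step of a 1.1-fold higher number from compound 1 to compound 4 (0.04 log units; within the scatter) reflects that expectation. Compound 4 is therefore estimated at 5000 nM in this assay, within 2000 nM to 13000 nM.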

Compound 4, half-maximal inhibitory concentration: 6000 nM
Compound 4: the middle estimate sits 1.2-fold (0.08 log units) below what was measured; low and high end bracket the measured number.
By their numbers in this assay, from the lowest: compounds 1 and 4 (each within the scatter of the next); then compound 3.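

Going by these compounds alone, changing 4-((tert-butoxycarbonyl)amino)butyl to 3-((tert-butoxycarbonyl)amino)propyl gives a 1.3-fold higher number from compound 1 to compound 4 (0.12 log units; within the scatter) in this assay, the first measured step at this position. The two chain lengths therefore cannot be told apart in this assay, so this shortening leaves binding effectively unchanged. Nothing available explains this result.

Going by these compounds, whether a still shorter 2-((tert-butoxycarbonyl)amino)ethyl chain or a longer chain would also read alike remains open. So does the outcome of putting a free amine or a carboxylic acid in place of the (tert-butoxycarbonyl)amino group.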